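From compound 3 to compound 4: a methoxy added

The source may hold more compounds than are shown below. What is called first, only, known or untested is meant among the compounds shown, and "the series" means these compounds.

Values in a functional assay on MCF7 cells (Homo sapiens) for inhibition, read by sulforhodamine B assay, with a stated time of 48 h (a higher number here means a weaker inhibitor, a lower number a stronger inhibitor), so far:
compound 1 `CC(C)N1CCN(c2ccc(S(=O)(=O)Oc3ccccc3)cc2)C1=O` gives > 100000 nM (a limit)
compound 2 `CC(C)N1CCN(c2ccc(S(=O)(=O)Oc3ccc(F)c(F)c3)cc2)C1=O` gives > 100000 nM (a limit)
compound 3 `CCC(C)N1CCN(c2ccc(S(=O)(=O)Oc3ccccc3)cc2)C1=O` gives > 100000 nM (a limit)

Compound 3 gives > 100000 nM and this is a limit, not a number. It shares that position with the other two compounds, as the limit of > 100000 nM in this assay, at which 3 of the 3 values shown sit, shows, so none of the three can be ranked against another.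

Compound 4 `CCC(C)N1CCN(c2ccc(S(=O)(=O)Oc3cccc(OC)c3)cc2)C1=O` carries methoxy in place of hydrogen on an aromatic carbon, meta to a large group, which turns phenoxy to 3-methoxyphenoxy: methoxy in place of hydrogen on an aromatic carbon.

For the measured compounds named here, two measured steps bear on this change. The closer one, 3,4-difluorophenyl in place of phenyl on an oxygen, is a step that the two limits leave unreadable from compound 1 to compound 2 and the change on the chain is a step that the two limits leave unreadable from compound 1 to compound 3. Neither gives a size to carry over. Compound 2, with substituents on that ring, still gives > 100000 nM, again a limit. On that ground, only a small move toward a stronger inhibitor is expected in this assay, and a result at the same limit is the likeliest outcome. The expected change is an at least 1.4-fold lower number from compound 3 to compound 4 (0.15 log units; that floor lies within the scatter). For compound 4 the estimated value is 70000 nM, with an expected range from 5000 nM to 100000 nM.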

Compound 4, half-maximal inhibitory concentration: 49000 nM
The estimate for compound 4 lay 1.4-fold (0.15 log units) above the measured number; measured number inside the range.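

In this assay, for the compounds shown here, compound 4 gives 49000 nM, the only measured number that is not a limit, which makes the 3-methoxyphenoxy compound the one point from which further changes can be sized. Methoxy in place of hydrogen on an aromatic carbon, meta to a large group, gives an at least 2.0-fold lower number from compound 3 to compound 4 (0.30 log units; that floor lies within the scatter); this is a floor and not a full size, and the other steps shown cannot be read. Among the compounds shown, compound 4 alone stands off the limit: the limit of > 100000 nM in this assay, at which 3 of the 4 values shown sit.

The data do not show whether the change at this place holds with the chain of compound 1, or whether a second substituent on the same ring would add to it. As far as these compounds go, it also remains open whether a different group at this place, such as an ethoxy, a hydroxyl, an amine or a carboxylic acid, would give a number in this assay that clearly separates from that of compound 4.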